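The compounds below may be only part of what the source reports. "The series", "measured", "known", "first", "only" and "open" are said of these compounds alone.

Measured compounds:
compound 1, `COC(=O)c1ccc(Nc2[nH]cnc3ncnc2-3)cc1` — 850 nM
compound 2, `CNc1cc2c(Nc3cccc(Br)c3)ncnc2cn1` — 1700 nM
compound 3, `CNc1ccc2ncc(-c3ccc(F)cc3)n2n1` — 4050 nM

All three numbers come from an assay on isolated protein for inhibition of MAP kinase-interacting serine/threonine-protein kinase 1 (Homo sapiens); a higher number here means a weaker inhibitor, a lower number a stronger inhibitor. Among them compound 3 stands highest: compound 2 gives a lower number, and the gap between the two lies beyond the usual scatter, while compound 1 gives the lowest number of the three, further from compound 3 than compound 2 is. Among the measured compounds shown here, none of these three pairs differs in only one place, so no single-point step is available from them.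

Compound 4, `COCCNc1ccc2ncc(-c3ccc(F)cc3)n2n1`, is the unmeasured neighbour of compound 3. The change is methoxymethyl in place of hydrogen on a saturated chain carbon bound to a nitrogen on an aromatic ring. For the measured compounds named here, there is no measured pair in this set that shows such a change, so the expectation rests on the structural change alone. In this assay the step from compound 3 to compound 4 is expected to be small, a 1.2-fold lower number from compound 3 to compound 4 (0.06 log units; within the scatter), and may well fall within the scatter in either direction. Compound 4 is therefore estimated at 3500 nM, with a range from 1200 nM to 10000 nM.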

Compound 4, half-maximal inhibitory concentration: 4090 nM
Compound 4: middle estimate off by 1.2-fold (0.07 log units), on the low side; low and high end bracket the measured number.
By their numbers in this assay, from the lowest: compounds 1 and 2 (each within the scatter of the next); then compounds 3 and 4 (each within the scatter of the next).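

In this assay the result is a 1.0-fold higher number from compound 3 to compound 4 (0.00 log units; within the scatter) with methoxymethyl in place of hydrogen on a saturated chain carbon bound to a nitrogen on an aromatic ring, so the two compounds cannot be told apart. Among the compounds shown here, this is the first comparison in the set that differs in only one place, and it shows that methylamino can give way to (2-methoxyethyl)amino on this core without a step beyond the scatter. No measurement at hand bears on why the two numbers agree.

The compounds shown leave open whether a chain ending in an amine or a carboxylic acid, or a longer chain, at this place would also stay within the scatter of compound 3. They also leave open whether (2-methoxyethyl)amino would behave the same way in place of the methylamino group of compound 2.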